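One Methyl Removed Twice in a Cytotoxicity Screen

The source may hold more compounds than are shown below. What is called first, only, known or untested is meant among the compounds shown, and "the series" means these compounds.

Compound 1 `COc1cc(C(=N)NC(C)C)ccc1-c1cc2cc(C(=N)NC(C)C)ccc2o1`: 98100 nM
Compound 2 `CC(C)NC(=N)c1ccc(-c2cc3cc(C(=N)NC(C)C)ccc3o2)c(O)c1`: > 183000 nM
Compound 3 `COc1ccc(C(=N)NC(C)C)cc1-c1cc2ccc(C(=N)NC(C)C)cc2o1`: > 175000 nM

Of the compounds shown here, three have been measured in an ADME assay on L6 cells (Rattus norvegicus) for cytotoxicity; a lower number here means a stronger inhibitor, a higher number a weaker inhibitor. Compound 1 gives 98100 nM. For compound 2 the assay reports only a limit, > 183000 nM. For compound 3 the assay likewise reports only a limit, > 175000 nM. Compound 1 and compound 3 are built from the same atoms joined differently; the difference between the two cores is not broken down here.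

The change from compound 1 to compound 2 is hydrogen in place of methyl on an oxygen on an aromatic ring. That step gave an at least 1.8-fold higher number from compound 1 to compound 2 (0.27 log units; that floor lies within the scatter), and its true size is hidden by the limit of > 183000 nM in this assay, at which 1 of the 3 values shown sits. Compound 4 `CC(C)NC(=N)c1ccc(O)c(-c2cc3ccc(C(=N)NC(C)C)cc3o2)c1` differs from compound 3 by hydrogen in place of methyl on an oxygen on an aromatic ring, the same change in the same kind of place, so the change occurs twice among these four compounds.

For compound 4 the expectation rests on compound 3, which already sits at the limit of > 175000 nM in this assay, at which 1 of the 3 values shown sits, and on the earlier step of an at least 1.8-fold higher number from compound 1 to compound 2 (0.27 log units; that floor lies within the scatter), which did not move compound 2 below its limit. Compound 4 is therefore expected to show a step that the limit leaves unreadable from compound 3 to compound 4. Compound 4 is estimated at 200000 nM, with a likely range from 120000 nM to 400000 nM, and the result is expected most often to come back as a limit rather than a number.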

Compound 4, half-maximal inhibitory concentration: > 187000 nM
Compound 4 gave a limit, no number (the forecaster's own chance of this, stated with the estimate: 75%); the middle value lies beyond the limit too.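

In this assay compound 4 gives > 187000 nM, which is a limit and not a number. Compound 3 also carries only a limit, and no step can be read between compound 3 and compound 4. What the compounds shown leave open is how large the change from methoxy to hydroxy truly is on either core, and whether its size is the same on both.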